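A few compounds are considered here, and "the series" means these few. Any claim that something is new, unique, unknown or untested is made for them only; others in the source may bear on it.

In a functional assay on MGC-803 cells (Homo sapiens) for inhibition, read by sulforhodamine B assay (on this read-out lower numbers stand for stronger inhibition and higher numbers for weaker inhibition), compound 3 `Cc1ccc(NC2=CC(=O)c3nc4n(c3C2=O)[C@H]2OC[C@@H](O)[C@H]2OC4)cc1` gives 1420 nM. That lies within the scatter of compound 1 `CCCc1ccc(NC2=CC(=O)c3nc4n(c3C2=O)[C@H]2OC[C@@H](O)[C@H]2OC4)cc1` at 1560 nM and of compound 2 `O=C1C=C(Nc2cccc(F)c2)C(=O)c2c1nc1n2[C@H]2OC[C@@H](O)[C@H]2OC1` at 2180 nM. Compound 4 `O=C1C=C(Nc2ccccc2)C(=O)c2c1nc1n2[C@H]2OC[C@@H](O)[C@H]2OC1` differs from compound 3 by hydrogen in place of methyl on an aromatic carbon. The closest evidence is a 1.1-fold lower number from compound 1 to compound 3 (0.04 log units; within the scatter), a change in the same alkyl group. Two further changes of the aryl group on the amine nitrogen are a 1.5-fold lower number from compound 2 to compound 3 (0.19 log units; within the scatter) and a 1.4-fold higher number from compound 1 to compound 2 (0.15 log units; within the scatter). All three stay within the scatter, so no step beyond the scatter is expected in this assay, and no firm direction. The expected step is a 1.2-fold higher number from compound 3 to compound 4 (0.08 log units; within the scatter). Compound 4 is estimated at 1700 nM, with an expected range of 800 nM to 3400 nM.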

Compound 4, half-maximal inhibitory concentration: 1730 nM
For compound 4 the middle estimate is 1.0-fold (0.01 log units) below the measured one; the measured number falls inside the stated range.
By their numbers in this assay, from the lowest: compounds 3, 1, 4 and 2 (each within the scatter of the next).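

In this assay, bare phenyl as the group on the amine nitrogen gives a 1.2-fold higher number from compound 3 to compound 4 (0.09 log units; within the scatter) for loss of methyl and a 1.3-fold lower number from compound 2 to compound 4 (0.10 log units; within the scatter) for loss of fluoro and a 1.1-fold higher number from compound 1 to compound 4 (0.04 log units; within the scatter) for loss of propyl. Hydrogen on this ring therefore cannot be told apart from any of these three substituents, all steps staying within the scatter. No accompanying measurement speaks to the reason for these small steps. As far as these compounds go, whether a carboxylic acid or an amine on this ring would shift the number beyond the scatter stays open. The same holds for a chain longer than propyl.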